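A few compounds are considered here, and "the series" means these few. Any claim that something is new, unique, unknown or untested is made for them only; others in the source may bear on it.

In a functional assay on NCI-H661 cells (Homo sapiens) for antiproliferative activity, read by MTT assay, with a stated time of 72 h (a lower number here means a stronger inhibitor, a higher number a weaker inhibitor), compound 1 `COc1ccc(-c2noc(CCCCCCC(=O)NO)n2)cc1` gives 20400 nM and compound 2 `O=C(CCCCCCc1nc(-c2ccccc2)no1)C(F)(F)F` gives 520 nM while compound 3 `Cc1ccc(-c2noc(CCCCCCC(=O)C(F)(F)F)n2)cc1` gives 18700 nM on the same read-out. Compound 3 thus lies level with compound 1, within the scatter, and well above compound 2. Compound 4 `COc1ccc(-c2noc(CCCCCCC(=O)C(F)(F)F)n2)cc1` has methoxy in place of methyl on an aromatic carbon, para to a large group, and methoxy in place of methyl on an aromatic carbon sums up that change. Among the measured compounds shown here, only one measured step bears on this, and a 36-fold higher number from compound 2 to compound 3 (1.56 log units; beyond the scatter) is large and beyond the scatter, with methyl in place of hydrogen on an aromatic carbon. For the measured compounds named here, one change at an aromatic carbon has therefore moved the number strongly, yet no measured pair sets methyl against methoxy. Compound 4 shares 4-methoxyphenyl with compound 1, but the two differ elsewhere, so the value of compound 1 settles little. With so little to go on, a modest move toward a lower number is expected in this assay with a wide margin. The expected change is a 1.3-fold lower number from compound 3 to compound 4 (0.13 log units; within the scatter) in this estimate. For compound 4 the estimated value is 14000 nM with an expected range from 3000 nM to 40000 nM as the likely span.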

Compound 4, half-maximal inhibitory concentration: 5050 nM
Beside the measured number, compound 4's estimate is 2.8-fold (0.44 log units) above it; measured number inside the range.
By their numbers in this assay, from the lowest: compound 2; then compound 4; then compounds 3 and 1 (each within the scatter of the next).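

Among the compounds shown here, at this aromatic carbon, para to a large group, the earlier compounds showed only what methyl does in place of hydrogen; in this assay, methoxy in place of methyl recovers part of that loss, with a 3.7-fold lower number from compound 3 to compound 4 (0.57 log units; beyond the scatter), yet methoxy in place of hydrogen still leaves a 9.7-fold higher number from compound 2 to compound 4 (0.99 log units; beyond the scatter). For the compounds shown here, the result also gives the first one-place comparison at the other end of the chain: with 4-methoxyphenyl held constant, trifluoromethyl in place of hydroxyamino on the carbonyl carbon gives a 4.0-fold lower number from compound 1 to compound 4 (0.61 log units; beyond the scatter). No evidence available here accounts for either change.

On these data alone, it remains open whether a chlorine or an amine at this aromatic carbon would follow methyl or methoxy. Also open, as far as these compounds go, is whether the difference between trifluoromethyl and hydroxyamino would hold with an unsubstituted phenyl or a longer chain.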